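The source may hold more compounds than are shown below. What is called first, only, known or untested is meant among the compounds shown, and "the series" means these compounds.

Compound 1 `O=C(O)CCCO/N=c1/ccn([C@@H]2O[C@H](COP(=O)(O)OP(=O)(O)OP(=O)(O)O)[C@@H](O)[C@H]2O)c(=O)[nH]1`, compound 2 `O=c1[nH]/c(=N\OCCCc2ccc(F)cc2)ccn1[C@@H]1O[C@H](COP(=O)(O)OP(=O)(O)OP(=O)(O)O)[C@@H](O)[C@H]1O` and compound 3 `O=c1[nH]/c(=N\OCCCc2ccc(I)cc2)ccn1[C@@H]1O[C@H](COP(=O)(O)OP(=O)(O)OP(=O)(O)O)[C@@H](O)[C@H]1O` share one core and differ only in the group at the end of the chain that hangs from the oxygen on an unsaturated carbon. In a functional assay on 1321-N1 cells for agonist activity at P2Y purinoceptor 4 (Homo sapiens), read by scintillation counting and inositol phosphate accumulation (a lower number here means that less compound is needed, a higher number that more compound is needed for the effect), compound 1 gives 470 nM, compound 2 gives 105 nM and compound 3 gives 91 nM. Compound 3 and compound 2 lie within the scatter of each other, as a 1.2-fold lower number from compound 2 to compound 3 (0.06 log units; within the scatter), while both stand apart from compound 1: a 4.5-fold lower number from compound 1 to compound 2 (0.65 log units; beyond the scatter) and a 5.2-fold lower number from compound 1 to compound 3 (0.71 log units; beyond the scatter). Exchanging the carboxy group for either halophenyl group thus brought a modest gain, and the choice of halogen made no difference that the scatter would not cover.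

Compound 4 `C#CCCCO/N=c1/ccn([C@@H]2O[C@H](COP(=O)(O)OP(=O)(O)OP(=O)(O)O)[C@@H](O)[C@H]2O)c(=O)[nH]1` takes the chain end in another direction: ethynyl in place of 4-iodophenyl on a saturated chain carbon, three bonds along the chain from an oxygen. Within the data shown here, no measured step moves from an aryl group to a small unsaturated group, so the only anchors are the modest gains from compound 1 to compound 2 and compound 3. Losing the aryl ring is expected to give back part of that gain, so the estimate is a 2.7-fold higher number from compound 3 to compound 4 (0.44 log units; beyond the scatter). Compound 4 is therefore expected to show about 250 nM, with a range from 100 nM to 650 nM.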

Compound 4, half-maximal effective concentration: 410 nM
Estimate against measurement, compound 4: 1.6-fold (0.21 log units) below; measured number inside the range.
By their numbers in this assay, from the lowest: compounds 3 and 2 (each within the scatter of the next); then compounds 4 and 1 (each within the scatter of the next).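

In this assay, the ethynyl chain end does not keep the gain seen with the halophenyl groups: the change is a 4.5-fold higher number from compound 3 to compound 4 (0.65 log units; beyond the scatter) and, against the fluorinated ring, a 3.9-fold higher number from compound 2 to compound 4 (0.59 log units; beyond the scatter) so the two-carbon triple-bonded end does not stand in for a 4-iodophenyl or 4-fluorophenyl ring at this place on the chain. The comparison with the carboxy compound adds a second point, since the step is a 1.1-fold lower number from compound 1 to compound 4 (0.06 log units; within the scatter) and exchanging the carboxy group for ethynyl therefore brings no measurable gain. Among these four compounds, the lower numbers belong only to the two with a halophenyl end, compound 2 and compound 3, while the ethynyl and carboxy ends cannot be told apart, and no measurement at hand explains this difference.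

The compounds shown leave open whether a plain phenyl ring with no halogen would match compound 2 and compound 3, and so whether the ring alone accounts for the lower numbers. They also leave open how an amine at the chain end would compare, and whether a longer chain carrying the 4-iodophenyl ring would keep the gain.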